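Phenoxy for acetyl on a diaryl urea

The source may hold more compounds than are shown below. What is called first, only, known or untested is meant among the compounds shown, and "the series" means these compounds.

Measured compounds:
compound 1 `CC(=O)Nc1cc(NC(=O)Nc2cccc(Oc3ccccc3)c2)ccc1C`, > 30000 nM (a limit)
compound 2 `Cc1ccc(NC(=O)Nc2ccccc2Cl)cc1NC(=O)c1ccccc1`, > 30000 nM (a limit)
compound 3 `CC(=O)c1cccc(NC(=O)Nc2ccc(C)c(NC(=O)c3ccccc3)c2)c1`, 9800 nM

In a functional assay on A375P cells (Homo sapiens) for antiproliferative activity (a lower number here means a stronger inhibitor, a higher number a weaker inhibitor), compound 1 reaches only the assay limit of > 30000 nM. Compound 2 likewise gives no number but the limit > 30000 nM. Within the data shown here, compound 3 is the one compound with a measured value and gives 9800 nM in this assay. Among the measured compounds shown here, the single step between measured compounds is an at least 3.0-fold lower number from compound 2 to compound 3 (0.48 log units; beyond the scatter), and it is read against (the limit of > 30000 nM in this assay, at which 2 of the 3 values shown sit), so its true size is not fixed.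

Compound 4 `Cc1ccc(NC(=O)Nc2cccc(Oc3ccccc3)c2)cc1NC(=O)c1ccccc1` is not yet measured. It arises from compound 3 by phenoxy in place of acetyl on an aromatic carbon. For the measured compounds named here, no measured step swaps these two groups, so the step from compound 2 to compound 3 bears on it only as a sign that changes at this ring do shift the read-out. Compound 1, which carries the same phenoxy group with a different amide, sits at its limit, which lends no support to a gain. The estimate for compound 4 is therefore close to compound 3, with a slight lean to the weaker side: a 1.2-fold higher number from compound 3 to compound 4 (0.09 log units; within the scatter) is expected, and compound 4 is expected at 12000 nM, within 2500 nM to 30000 nM.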

Compound 4, half-maximal inhibitory concentration: > 30000 nM
Compound 4: only a limit was reported; the forecaster's own chance of this, stated with the estimate: 35%; middle value at least 2.5-fold (0.39 log units) from the limit.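

In this assay, among these compounds, phenoxy in place of acetyl on this aromatic carbon gives an at least 3.0-fold higher number from compound 3 to compound 4 (0.48 log units; beyond the scatter), which shows that the 3-acetylphenyl side of the urea does not tolerate this exchange in the one compound with a measured value. Compound 4 gives > 30000 nM, which is a limit and not a number. Of the compounds that keep the benzoyl amide of compound 3, only compound 3 itself now gives a number, while the step between compound 1 and compound 4 cannot be read and the true size of the loss is not fixed: the limit of > 30000 nM in this assay, at which 3 of the 4 values shown sit.

What the compounds shown leave open is whether acetyl is needed as such, or whether another group on this aromatic carbon, such as a methoxy group, a nitrile, an amine or a carboxylic acid, would match or improve on compound 3 at 9800 nM. They also leave open how far compound 4 and compound 1 actually differ, since neither has a value inside the range of this assay.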